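Replacing 4-methylpiperazin-1-yl: notes on compound 4

The source may hold more compounds than are shown below. What is called first, only, known or untested is meant among the compounds shown, and "the series" means these compounds.

Measured in a functional assay on NCI-H1975 cells (Homo sapiens) for inhibition, read by MTT assay, with a stated time of 72 h; on this read-out higher numbers stand for weaker inhibition and lower numbers for stronger inhibition:
compound 1 `CN1CCN(c2cc(C(F)(F)F)nc(SCc3ccc(C(F)(F)F)cc3)n2)CC1`: 23900 nM
compound 2 `FC(F)(F)c1ccc(CSc2nc(N3CCN(c4ccccn4)CC3)cc(C(F)(F)F)n2)cc1`: 17400 nM
compound 3 `FC(F)(F)c1ccc(CSc2nc(Sc3nncs3)cc(C(F)(F)F)n2)cc1`: 2270 nM
Not yet measured: compound 4 `FC(F)(F)c1ccc(CSc2nc(SC3=NCCS3)cc(C(F)(F)F)n2)cc1`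

Compound 1 sits at the high end of these numbers, and the pyridin-2-yl swap barely moves it: a 1.4-fold lower number from compound 1 to compound 2 (0.14 log units; within the scatter). That step leaves 4-methylpiperazin-1-yl in place, so it bears little on the change at hand: a group of 6 heavy atoms (3 carbon, 1 nitrogen, 2 sulfur; one five-membered non-aromatic ring with 2 hetero atoms) in place of a group of 7 heavy atoms (5 carbon, 2 nitrogen; one six-membered non-aromatic ring with 2 hetero atoms), on an aromatic carbon. The closest guide is the replacement of the same group on the same aromatic carbon, a large step: an 11-fold lower number from compound 1 to compound 3 (1.02 log units; beyond the scatter). The entering ring here is non-aromatic, so a lower number in this assay is expected, of similar or somewhat smaller size. The expected step is a 6.0-fold lower number from compound 1 to compound 4 (0.78 log units; beyond the scatter). For compound 4 the estimated value is 4000 nM, with an expected range of 1500 nM to 11000 nM.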

Compound 4, half-maximal inhibitory concentration: 24200 nM
Compound 4: middle estimate off by 6.1-fold (0.78 log units), on the low side; measured number above the stated range.
By their numbers in this assay, from the lowest: compound 3; then compounds 2, 1 and 4 (each within the scatter of the next).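

In this assay, a sulfur-linked five-membered ring at this aromatic carbon does not by itself give a lower number: the non-aromatic ring leaves the read-out level with the 4-methylpiperazin-1-yl group (a 1.0-fold higher number from compound 1 to compound 4 (0.01 log units; within the scatter)). With the sulfur link held, the aromatic 1,3,4-thiadiazol-2-yl ring and this non-aromatic ring stand far apart (an 11-fold higher number from compound 3 to compound 4 (1.03 log units; beyond the scatter)), so the sulfur link alone does not account for the lower number of compound 3. No evidence is available that explains this gap.

Going by these compounds, whether aromaticity or the ring nitrogens of compound 3 matter stays open. A phenyl or thiophene ring on the same sulfur would help separate the two.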